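The source may report more compounds than this note shows. Statements on the series, on what has been measured and on what is new or still open speak of the compounds shown alone.

Of the compounds shown here, two have been measured so far. Compound 1 `CC1(C)C=Cc2c(O)cc(/C=C/c3ccc(O)cc3)cc2O1` carries a stilbene-type arrangement, and compound 2 `COc1ccc(/C=C/c2c(CC=C(C)C)c(O)cc(O)c2CC=C(C)C)cc1` shares that arrangement but with two prenyl chains on the shared core and a methoxy group on the outer ring. In an assay on isolated protein for inhibition of Polyunsaturated fatty acid 5-lipoxygenase (Homo sapiens), read by ELISA (on this read-out lower numbers stand for stronger inhibition and higher numbers for weaker inhibition), compound 1 gives 2400 nM, while compound 2 gives 1100 nM. Compound 2 therefore stands at the lowest number of the two, and its distance from compound 1 is beyond the usual scatter of such measurements, so compound 2 reads as the stronger inhibitor of the pair.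

Compound 3 `COc1ccc(/C=C/c2c(CC=C(C)C)c(O)cc(O)c2CC=C(C)C)cc1O` is the next candidate. It differs from compound 2 in one place: hydroxy in place of hydrogen on an aromatic carbon. Within the data shown here, no measured pair shows what a change of this kind does here, so there is no direct guide. A modest move, most likely toward a somewhat lower number and possibly staying within the scatter, is expected. The change implied by this estimate, a 1.4-fold lower number from compound 2 to compound 3 (0.14 log units; within the scatter), is expected to be small. Compound 3 is expected to give 800 nM, with a range from 300 nM to 2500 nM.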

Compound 3, half-maximal inhibitory concentration: 900 nM
The estimate for compound 3 lay 1.1-fold (0.05 log units) below the measured number; the measured number falls inside the stated range.
By their numbers in this assay, from the lowest: compounds 3 and 2 (each within the scatter of the next); then compound 1.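

In this assay, placing a hydroxy group on the aromatic carbon ortho to the methoxy group gives a 1.2-fold lower number from compound 2 to compound 3 (0.09 log units; within the scatter), so this change cannot be told apart from the ordinary variation between repeated measurements. Among these compounds, this is the first comparison here between two compounds that differ in one place, and it shows that going from 4-methoxyphenyl to 3-hydroxy-4-methoxyphenyl leaves no readable change in inhibition. Nothing available bears on the reason for this result.

Going by these compounds, it remains open whether a different group at this same position, such as an amine, a carboxylic acid or an ethoxy group, would move the number beyond the scatter, and whether a hydroxy group on another carbon of this ring would do so. On these data alone, the effect of replacing the methoxy group itself, or of putting a shorter or longer chain in place of the prenyl chains, also remains open.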